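Swapping trifluoromethoxy for dichloro on the aryl group

The source may hold more compounds than are shown below. What is called first, only, known or untested is meant among the compounds shown, and "the series" means these compounds.

Among the compounds with values here, in a functional assay on NIH3T3 cells (Mus musculus) (on this read-out lower numbers stand for an effect already at smaller amounts and higher numbers for an effect only at larger amounts of compound), compound 1 `Cn1cncc1C(OCc1ccc(C#N)cc1-c1cccc(Cl)c1)c1ccc(C#N)nc1` gives 2.1 nM, and compound 2 `Cn1cncc1C(OCc1ccc(C#N)cc1-c1cccc(OC(F)(F)F)c1)c1ccc(C#N)nc1` gives 24 nM, the higher of the two numbers so far. Compound 3 `Cn1cncc1C(OCc1ccc(C#N)cc1-c1cc(Cl)cc(Cl)c1)c1ccc(C#N)nc1` has 3,5-dichlorophenyl in place of 3-(trifluoromethoxy)phenyl on an aromatic carbon. Within the data shown here, the one measured step that bears on this is trifluoromethoxy in place of chloro, an 11-fold higher number from compound 1 to compound 2 (1.06 log units; beyond the scatter), which is large and beyond the scatter. From the compounds shown here alone, compound 3 restores chloro, but a second chloro remains untested, so most of that step is expected to reverse. The expected change is a 6.0-fold lower number from compound 2 to compound 3 (0.78 log units; beyond the scatter). The estimated value for compound 3 is 4 nM, with an expected range of 1.2 nM to 14 nM.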

Compound 3, half-maximal effective concentration: 3.5 nM
Estimate against measurement, compound 3: 1.1-fold (0.06 log units) above; measured number inside the range.
By their numbers in this assay, from the lowest: compounds 1 and 3 (each within the scatter of the next); then compound 2.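

In this assay, 3,5-dichlorophenyl in place of 3-(trifluoromethoxy)phenyl brings the number back close to that of compound 1, with a 6.9-fold lower number from compound 2 to compound 3 (0.84 log units; beyond the scatter) on this position. The added chloro on the aryl group leaves the read-out within the scatter, with a 1.7-fold higher number from compound 1 to compound 3 (0.22 log units; within the scatter) here, so the second chloro is tolerated without a measurable change. Nothing available explains why chloro and trifluoromethoxy differ at this position.

From the compounds shown here alone, whether bromo or fluoro would match chloro here remains open. So does whether an amine or a carboxylic acid on the same aryl group would hold the number near that of compound 1.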